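The source may hold more compounds than are shown below. What is called first, only, known or untested is meant among the compounds shown, and "the series" means these compounds.

Measured in a functional assay on L1210 cells (Mus musculus) for inhibition; on this read-out lower numbers stand for stronger inhibition and higher numbers for weaker inhibition:
- compound 1 `O=C1O/C(=C\Cn2cc(C(F)(F)F)c(=O)[nH]c2=O)C(OCc2ccccc2)=C1OCc1ccccc1`: 2000 nM
- compound 2 `O=C1O/C(=C\Cn2cc(Cl)c(=O)[nH]c2=O)C(OCc2ccccc2)=C1OCc1ccccc1`: 12200 nM
- compound 3 `O=C1O/C(=C\Cn2cnc3c(-n4cccc4)ncnc32)C(OCc2ccccc2)=C1OCc1ccccc1`: 110000 nM

Compound 2 holds the middle place among these three numbers. Compound 1 shows a lower number at 2000 nM, and compound 3 shows a higher one at 110000 nM.

Next in the series is compound 4 `O=C1O/C(=C\Cn2cc(F)c(=O)[nH]c2=O)C(OCc2ccccc2)=C1OCc1ccccc1`, which keeps the shared core of compound 2 and changes one group: fluoro in place of chloro on an aromatic carbon. In words, this is fluoro in place of chloro on an aromatic carbon.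

For the measured compounds named here, only one measured step bears on this change: a 6.1-fold higher number from compound 1 to compound 2 (0.79 log units; beyond the scatter). It concerns the same aromatic carbon, and it is modest but beyond the scatter. Going by the values given here, compound 3 is linked to the others by no single-place step and offers no guide here.

That one step suggests that a swap of group at this carbon can move the number by a modest amount. In it, the chloro compound had the higher number, so a modest move towards a lower number is expected in this assay. The direction rests on this single step and is not secure.

The expected step is a 2.4-fold lower number from compound 2 to compound 4 (0.39 log units; beyond the scatter). For compound 4 the estimated value is 5000 nM, with an expected range of 1200 nM to 20000 nM.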

Compound 4, half-maximal inhibitory concentration: 5100 nM
Compound 4: middle estimate off by 1.0-fold (0.01 log units), on the low side, within the range that was stated.
By their numbers in this assay, from the lowest: compound 1; then compound 4; then compound 2; then compound 3.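

In this assay, this aromatic carbon responds even to the exchange of one single heavy atom for another, with no change in hydrogen-bond donors, hydrogen-bond acceptors or net charge (this swap gives a 2.4-fold lower number from compound 2 to compound 4 (0.38 log units; beyond the scatter)). The earlier step compared only chloro with trifluoromethyl; fluoro now falls between them (with a 2.6-fold higher number from compound 1 to compound 4 (0.41 log units; beyond the scatter)), so the three groups at this carbon rank trifluoromethyl lowest, fluoro in the middle and chloro highest, with each gap beyond the scatter. No measurement offered here accounts for this order.

For the compounds shown here, the order rests on only three groups at one position of the shared core, so it cannot yet be said how an amine, a nitrile, a carboxylic acid or a longer chain such as ethyl would rank at this carbon. On these data alone, it also remains open whether the same order would hold if the other parts of the shared core were changed, since every step here leaves them untouched.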